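The compounds below may be only part of what the source reports. "The series", "measured", "known", "first", "only" and "open" are said of these compounds alone.

Series notes. Among the measured compounds shown here, compound 3 `Nc1nccc2c1ncn2[C@H]1C[C@H](O)[C@@H](CO)O1` gives 89% in a functional assay on EL4 cells (Mus musculus) for inhibition, tested at 100 uM (on this read-out lower numbers stand for less inhibition and higher numbers for more inhibition at the one concentration tested (going by the name of the read-out)), the highest of the three numbers measured so far. Compound 2 `[N-]=[N+]=Nc1nccc2c1ncn2[C@H]1C[C@H](O)[C@@H](CO)O1` gives 13% in this assay, and compound 1 `OC[C@H]1O[C@@H](n2cnc3c(NCc4ccccc4)nccc32)C[C@@H]1O` gives 8%. Both steps toward compound 3 are large and beyond the scatter: a number 76 percentage points higher from compound 2 to compound 3 (beyond the scatter) and a number 81 percentage points higher from compound 1 to compound 3 (beyond the scatter). The remaining measured step, a number 5 percentage points higher from compound 1 to compound 2 (within the scatter), lies within the scatter, so the two groups other than amino at this aromatic carbon both leave inhibition low.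

Compound 4 `OC[C@H]1O[C@@H](n2cnc3c(S)nccc32)C[C@@H]1O` differs from compound 3 in one place: sulfanyl in place of amino on an aromatic carbon. For the measured compounds named here, no measured compound carries sulfanyl, so this change has no direct precedent. The step that bears on it most closely is a number 76 percentage points higher from compound 2 to compound 3 (beyond the scatter), which shows that the amino group accounts for most of the inhibition seen with compound 3; whether sulfanyl behaves like amino or like the two low-scoring groups cannot be read from the data. The expected step is therefore a decrease in this assay, large in size but uncertain.

For compound 4 the expected value in this assay is 35%, with a range from 8% to 80%. This corresponds to an expected step of a number 54 percentage points lower from compound 3 to compound 4 (beyond the scatter).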

Compound 4, a percentage reported as inhibition, at one concentration (the size of the read-out at that concentration, not a potency): < 5%
Compound 4: only a limit was reported (the forecaster's own chance of this, stated with the estimate: 0%); middle value at least 30 percentage points away from the limit.
By their numbers in this assay, from the lowest: compounds 1 and 2 (each within the scatter of the next); then compound 3. At a limit, below all of these: compound 4.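

In this assay, compound 4 is held only as a limit, not as a number: the limit of < 5% in this assay, at which 1 of the 4 values shown sits.

Amino and sulfanyl have the same counts of heavy atoms, hydrogen-bond donors and hydrogen-bond acceptors, yet the exchange on this aromatic carbon next to the ring nitrogen gives a number at least 84 percentage points lower from compound 3 to compound 4 (beyond the scatter), so matching those counts does not keep the inhibition seen with amino. The floors of the other two steps, a number at least 8 percentage points lower from compound 2 to compound 4 (that floor lies within the scatter) and a number at least 3 percentage points lower from compound 1 to compound 4 (that floor lies within the scatter), do not set sulfanyl apart from azido or benzylamino, which leaves amino as the only one of the four groups at this carbon with high inhibition and no compound shown going against that.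

The compounds shown leave open whether a close relative of amino, such as methylamino or hydroxyl, would keep inhibition at this carbon, and whether amino would still do so with a carboxylic acid in place of the hydroxymethyl group on the shared core. From the compounds shown here alone, with each compound read at a single concentration, the potency of compound 3 also remains open.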